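A few compounds are considered here, and "the series" means these few. Any claim that something is new, unique, unknown or untested is made for them only; others in the source may bear on it.

Compound 1 `FC(F)(F)c1ccc(CSc2nc(N3CCNCC3)cc(C(F)(F)F)n2)cc1`: 5870 nM
Compound 2 `CC(C)(C)OC(=O)N1CCN(c2cc(C(F)(F)F)nc(SCc3ccc(C(F)(F)F)cc3)n2)CC1`: 22200 nM
Compound 3 `FC(F)(F)c1ccc(CSc2nc(N3CCN(c4ccccn4)CC3)cc(C(F)(F)F)n2)cc1`: 23500 nM

These three compounds were tested in a functional assay on MGC-803 cells (Homo sapiens) for inhibition, read by MTT assay, with a stated time of 72 h; a lower number here means a stronger inhibitor, a higher number a weaker inhibitor. Compound 1, with its free ring amine, gives the lowest number of the three, and its steps to the other two both lie beyond the scatter. Compound 4 `FC(F)(F)c1ccc(CSc2nc(N3CCN(c4ncccn4)CC3)cc(C(F)(F)F)n2)cc1` has not yet been measured. It differs from compound 1 by pyrimidin-2-yl in place of hydrogen on an amine nitrogen in a ring, with pyrimidin-2-yl in place of hydrogen on an amine nitrogen in a ring.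

Two measured steps fill that same nitrogen. The closest guide is the pyridin-2-yl group, with a 4.0-fold higher number from compound 1 to compound 3 (0.60 log units; beyond the scatter), and the tert-butoxycarbonyl group gave a 3.8-fold higher number from compound 1 to compound 2 (0.58 log units; beyond the scatter). Both are modest, and the two substituted compounds cannot be told apart, with a 1.1-fold higher number from compound 2 to compound 3 (0.02 log units; within the scatter). A modest rise of similar size is therefore expected in this assay. The estimate amounts to a 3.6-fold higher number from compound 1 to compound 4 (0.55 log units; beyond the scatter). For compound 4 the expected value is 21000 nM, with an estimated range from 9000 nM to 50000 nM.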

Compound 4, half-maximal inhibitory concentration: 35200 nM
The estimate for compound 4 lay 1.7-fold (0.22 log units) below the measured number; the range from low to high includes it.
By their numbers in this assay, from the lowest: compound 1; then compounds 2, 3 and 4 (each within the scatter of the next).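

With pyrimidin-2-yl on the amine nitrogen in the ring, this assay gives a 6.0-fold higher number from compound 1 to compound 4 (0.78 log units; beyond the scatter), so all three groups shown on this nitrogen now sit beyond the scatter from the free amine of compound 1. The added ring nitrogen of pyrimidin-2-yl does not separate it from pyridin-2-yl, with a 1.5-fold higher number from compound 3 to compound 4 (0.18 log units; within the scatter), and replacing tert-butoxycarbonyl gives a 1.6-fold higher number from compound 2 to compound 4 (0.20 log units; within the scatter), so these three quite different groups cannot be told apart in this assay. No measurement at hand explains why the unsubstituted amine gives the lowest number.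

The compounds shown leave open whether a simple methyl group or an acetyl group on this nitrogen would stay close to compound 1 or join the other three. They also leave open whether a chain ending in a primary amine or a carboxylic acid would do either.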